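The source may report more compounds than this note shows. Statements on the series, on what has been measured and on what is new or still open speak of the compounds shown alone.

Measured compounds:
- compound 1, `CC#C[C@@H](Cc1nnn[nH]1)c1ccc(OCc2ccc3scc(-c4cccnc4C)c3c2)cc1`: 0.183 h
- compound 2, `CC#C[C@@H](Cc1nnn[nH]1)c1ccc(OCc2ccc3scc(-c4ccc(OCCCS(C)(=O)=O)cc4C)c3c2)cc1`: 1.48 h
- compound 3, `CC#C[C@@H](Cc1nnn[nH]1)c1ccc(OCc2ccc3scc(-c4ccc(OCCOC)cc4C)c3c2)cc1`: 0.217 h

In an ADME assay on microsomes from liver (Rattus norvegicus) for metabolic stability (on this read-out lower numbers stand for a shorter-lived compound and higher numbers for a longer-lived compound), compound 3 gives 0.217 h, the second highest of the three numbers. Its nearest neighbour is compound 1: the step is a 1.2-fold higher number from compound 1 to compound 3 (0.07 log units; within the scatter). The furthest is compound 2: the step is a 6.8-fold lower number from compound 2 to compound 3 (0.83 log units; beyond the scatter).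

Compound 4, `CC#C[C@@H](Cc1nnn[nH]1)c1ccc(OCc2ccc3sc(C(F)(F)F)c(-c4ccc(OCCOC)cc4C)c3c2)cc1`, differs from compound 3 in one place: trifluoromethyl in place of hydrogen on an aromatic carbon.

Neither measured step bears on this change. Among the measured compounds shown here, the step from compound 1 to compound 3 and the step from compound 2 to compound 3 both concern groups elsewhere in the molecule, and no measured pair in this set varies the aromatic carbon changed here. There is therefore no measured basis for a step beyond the scatter in this assay, in either direction.

The step from compound 3 to compound 4 is accordingly expected to be a 1.4-fold higher number from compound 3 to compound 4 (0.14 log units; within the scatter). Compound 4 is estimated at 0.3 h in this assay, with a range from 0.12 h to 0.8 h.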

Compound 4, half-life: > 3 h
Compound 4 ended at the assay's limit; the forecaster's own chance of this, stated with the estimate: 5%; at least 10-fold (1.00 log units) between middle value and limit.
By their numbers in this assay, from the lowest: compounds 1 and 3 (each within the scatter of the next); then compound 2. At a limit, above all of these: compound 4.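

In this assay, among the compounds shown here, the change to trifluoromethyl on the aromatic carbon next to the ring sulfur gives an at least 13-fold higher number from compound 3 to compound 4 (1.14 log units; beyond the scatter) and is the first measured change at this position. Until now only a change on the aryl group had given a step beyond the scatter, a 6.8-fold lower number from compound 2 to compound 3 (0.83 log units; beyond the scatter) in the chain comparison, and the carbon of the five-membered aromatic ring now does so as well. Compound 4 gives > 3 h as a limit of the assay, not as a number: the limit of > 3 h in this assay, at which 1 of the 4 values shown sits.

As far as these compounds go, how far compound 4 lies past this limit stays open, and so does whether trifluoromethyl at this carbon gives a similar step with the aryl groups of compound 1 or compound 2. Also open, from the compounds shown here alone, is whether a methyl, a chlorine or a nitrile on the same carbon would move the half-life in the same direction.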